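Methoxy in place of methyl: compound 3 to compound 4

The source may hold more compounds than are shown below. What is called first, only, known or untested is meant among the compounds shown, and "the series" means these compounds.

In an ADME assay on CHO cells (Cricetulus griseus) for cytotoxicity, read by LDH release (on this read-out lower numbers stand for stronger inhibition and higher numbers for weaker inhibition), compound 1 (`CC(Oc1ccc(Cl)cc1Cl)C(=O)NCc1ccccc1`) gives 95000 nM, compound 2 (`CC(Oc1ccc(Cl)cc1Cl)C(=O)NCc1ccc(Cl)cc1`) gives 39000 nM and compound 3 (`Cc1ccc(CNC(=O)C(C)Oc2ccc(Cl)cc2Cl)cc1`) gives 25000 nM. Compound 3 lies within the scatter of compound 2 and beyond the scatter from compound 1. Compound 4 (`COc1ccc(CNC(=O)C(C)Oc2ccc(Cl)cc2Cl)cc1`) carries methoxy in place of methyl on an aromatic carbon, para to a large group: methoxy in place of methyl on an aromatic carbon. Replacing hydrogen at that carbon gave modest steps, a 2.4-fold lower number from compound 1 to compound 2 (0.39 log units; beyond the scatter) and a 3.8-fold lower number from compound 1 to compound 3 (0.58 log units; beyond the scatter). Going by the values given here, the one measured exchange of substituents, a 1.6-fold lower number from compound 2 to compound 3 (0.19 log units; within the scatter), stayed within the scatter, and no measured compound carries methoxy. The expected change is a 1.1-fold higher number from compound 3 to compound 4 (0.05 log units; within the scatter), with no step beyond the scatter in either direction. For compound 4 the estimate is 28000 nM, with an expected range of 11000 nM to 65000 nM.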

Compound 4, half-maximal inhibitory concentration: 71000 nM
For compound 4 the middle estimate is 2.5-fold (0.40 log units) below the measured one; measured number outside the range, above it.
By their numbers in this assay, from the lowest: compounds 3, 2, 4 and 1 (each within the scatter of the next, the first and the last beyond it).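

In this assay, going by these compounds alone, methoxy in place of methyl gives a 2.8-fold higher number from compound 3 to compound 4 (0.45 log units; beyond the scatter) and is the first exchange of substituents at this aromatic carbon to leave the scatter. Methoxy in place of chloro gives a 1.8-fold higher number from compound 2 to compound 4 (0.26 log units; within the scatter) and methoxy in place of hydrogen gives a 1.3-fold lower number from compound 1 to compound 4 (0.13 log units; within the scatter) and both stay within it. Chloro and methyl each stand beyond the scatter from hydrogen, whereas methoxy does not.

Going by these compounds, whether an amine or a carboxylic acid at this carbon would sit with methoxy or with methyl remains open. No available evidence bears on the step from methyl to methoxy.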